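The compounds below may be only part of what the source reports. "The series", "measured", "known", "first", "only" and "open" are said of these compounds alone.

Working notes on the series, metabolic stability arm.

Compound 1 `Nc1ccc(S(=O)(=O)N2CCN(c3ncc(C(O)(C(F)(F)F)C(F)(F)F)cc3-c3ccccc3O)CC2)cn1` is the reference point. In an ADME assay (liver) for metabolic stability, with Liver microsome (Homo sapiens) as the target, using microsomes and NADPH, with a stated time of 30 min, tested at 1 uM (on this read-out higher numbers stand for fast clearance and lower numbers for slow clearance), compound 1 gives 22 mL.min-1.g-1, the lowest of the three numbers available, though none of the other two stands apart from it beyond the scatter. Compound 2 `CS(=O)(=O)c1ccc(-c2cc(C(O)(C(F)(F)F)C(F)(F)F)cnc2N2CCN(S(=O)(=O)c3ccc(N)nc3)CC2)cc1` gives 32 mL.min-1.g-1 in this assay, and compound 3 `COc1cncc(-c2cc(C(O)(C(F)(F)F)C(F)(F)F)cnc2N2CCN(S(=O)(=O)c3ccc(N)nc3)CC2)c1` gives 44 mL.min-1.g-1. The step of a 1.5-fold higher number from compound 1 to compound 2 (0.16 log units; within the scatter) and the step of a 2.0-fold higher number from compound 1 to compound 3 (0.30 log units; within the scatter) both replace the same 2-hydroxyphenyl group with a different aromatic group, and neither moves the read-out beyond the scatter; the same holds for a 1.4-fold higher number from compound 2 to compound 3 (0.14 log units; within the scatter).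

Compound 4 `Nc1ccc(S(=O)(=O)N2CCN(c3ncc(C(O)(C(F)(F)F)C(F)(F)F)cc3-c3ccc4[nH]ncc4c3)CC2)cn1` continues this pattern of exchanging the aromatic group on the shared core: 1H-indazol-5-yl in place of 2-hydroxyphenyl on an aromatic carbon. Both measured exchanges at this position, compound 1 to compound 2 and compound 1 to compound 3, stayed within the scatter, so no step beyond the scatter is expected here either, if anything a slight drift towards higher numbers. The expected step is a 1.4-fold higher number from compound 1 to compound 4 (0.13 log units; within the scatter). Compound 4 is estimated at 30 mL.min-1.g-1 in this assay, with a range from 15 mL.min-1.g-1 to 60 mL.min-1.g-1.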

Compound 4, intrinsic clearance in microsomes: 27 mL.min-1.g-1
For compound 4 the middle estimate is 1.1-fold (0.05 log units) above the measured one, and the stated range covers the measured number.
By their numbers in this assay, from the lowest: compounds 1, 4, 2 and 3 (each within the scatter of the next).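

At this place on the shared core, two atoms from the ring nitrogen, 1H-indazol-5-yl adds a five-membered aromatic ring with 2 hetero atoms to the six-membered aromatic ring of carbon only, and in this assay the comparisons read a 1.2-fold higher number from compound 1 to compound 4 (0.09 log units; within the scatter) and a 1.2-fold lower number from compound 2 to compound 4 (0.07 log units; within the scatter) and also a 1.6-fold lower number from compound 3 to compound 4 (0.21 log units; within the scatter) with no step beyond the scatter. Compound 1, compound 2, compound 3 and compound 4 thus stay within the scatter of one another, and among these four groups a second aromatic ring does not separate compound 4 from the others. No measurement shown offers any explanation for this read-out.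

On these data alone, all four groups at this place are aromatic, so the effect of an open-chain amine or a carboxylic acid there remains open. As far as these compounds go, the 2,2,2-trifluoro-1-hydroxy-1-(trifluoromethyl)ethyl group is common to all four compounds, so the effect of exchanging it also remains open.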